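Thienopyridine carboxamides: amide aryl swap, fluoro to nitro

This account rests on a few compounds, and the source may have more. Where it says the series, first, only, none or still open, it means among the compounds named here.

Measured so far:
- Compound 1 `N#Cc1ccccc1CN1CCc2c(sc(NC(=O)c3ccccc3Cl)c2C(N)=O)C1` gives in a functional assay on HeLa cells (Homo sapiens) for antiproliferative activity, with a stated time of 24 h (a lower number here means a stronger inhibitor, a higher number a weaker inhibitor), the value > 50000 nM, which is a limit of the assay rather than a number.
- Compound 2 `NC(=O)c1c(NC(=O)c2ccc(C(F)(F)F)cc2)sc2c1CCN(Cc1ccccc1F)C2` gives in this assay the value > 50000 nM, likewise a limit and not a number.
- Compound 3 `NC(=O)c1c(NC(=O)c2ccccc2F)sc2c1CCN(C(=S)Nc1cc(C(F)(F)F)cc(C(F)(F)F)c1)C2` gives in this assay the value 28000 nM.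

Within the data shown here, compound 3 thus holds the only actual number in the set; the other two sit at the limit of > 50000 nM in this assay, at which 2 of the 3 values shown sit. Among the measured compounds shown here, no pair of measured compounds differs in a single place, so no measured step is available to calibrate the next change.

Compound 4 `NC(=O)c1c(NC(=O)c2cccc([N+](=O)[O-])c2)sc2c1CCN(C(=S)Nc1cc(C(F)(F)F)cc(C(F)(F)F)c1)C2` keeps the thiourea-bearing core of compound 3 and alters only the amide aryl group: 3-nitrophenyl in place of 2-fluorophenyl on a carbonyl carbon. For the measured compounds named here, with no measured step on this position, the expectation is a change no larger than the usual scatter, with a slight lean toward a weaker value; the step from compound 3 to compound 4 is estimated at a 1.3-fold higher number from compound 3 to compound 4 (0.10 log units; within the scatter). Compound 4 is therefore expected in this assay at about 35000 nM, within a range from 10000 nM to 120000 nM, with a fair chance that only a limit is returned.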

Compound 4, half-maximal inhibitory concentration: 27200 nM
Compound 4: middle estimate off by 1.3-fold (0.11 log units), on the high side, and the stated range covers the measured number.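

In this assay the amide aryl position now has its first measured step, a 1.0-fold lower number from compound 3 to compound 4 (0.01 log units; within the scatter), for 3-nitrophenyl in place of 2-fluorophenyl on a carbonyl carbon. On the thiourea-bearing core of compound 3, this swap of one aryl group for another therefore gives no separation between the two compounds. Compound 3 and compound 4 both return actual numbers, while the remaining values are a limit of the assay and not numbers: the limit of > 50000 nM in this assay, at which 2 of the 4 values shown sit.

On these data alone, one step cannot show how far this position tolerates change, and a phenyl bearing an amine or a carboxylic acid, or a longer alkyl chain in place of the aryl ring, remains open. Compound 1 and compound 2 differ from compound 3 and compound 4 in more than one place, so the contribution of the thiourea cannot be read from the compounds shown.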